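The compounds below may be only part of what the source reports. "The series", "measured", "known", "first", "only" and "open" are said of these compounds alone.

Of the compounds shown here, two of a shared core have been measured in an assay on HeLa cells for displacement of a labelled ligand from 5-hydroxytryptamine receptor 6 (Homo sapiens); a higher number here means a weaker inhibitor, a lower number a stronger inhibitor. Compound 1 `CCN1CCN(c2cn(S(=O)(=O)c3cc(OC)ccc3OC)c3cc(Cl)ccc23)CC1` gives 63.5 nM in this assay, and compound 2 `CN1CCN(c2cn(S(=O)(=O)c3ccccc3Br)c3cc(Cl)ccc23)CC1` gives 30.2 nM. Of these two numbers, compound 1 has the higher one, and compound 2 sits below it by a gap that goes beyond the usual scatter, so compound 2 is the stronger inhibitor of the pair. The two compounds differ in more than one place, so no single change can be tied to this gap.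

Compound 3 `CCN1CCN(c2cn(S(=O)(=O)c3ccc(OC)cc3)c3cc(Cl)ccc23)CC1` has not yet been measured. It departs from compound 1 in one place: 4-methoxyphenyl in place of 2,5-dimethoxyphenyl on a sulfonyl sulfur. Among the compounds with values here, nothing among the measured compounds isolates this change, so no step is known for it. Without such a step, the expectation for this assay is that compound 3 lands near compound 1, with the step from compound 1 to compound 3 estimated at a 1.3-fold higher number from compound 1 to compound 3 (0.10 log units; within the scatter), which is not beyond the scatter. On that basis compound 3 is expected to give about 80 nM in this assay, with a likely range from 25 nM to 250 nM.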

Compound 3, inhibition constant: 82.3 nM
Compound 3: middle estimate off by 1.0-fold (0.01 log units), on the low side, and the stated range covers the measured number.
By their numbers in this assay, from the lowest: compound 2; then compounds 1 and 3 (each within the scatter of the next).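

Within the data shown here, on a sulfonyl sulfur, 4-methoxyphenyl in place of 2,5-dimethoxyphenyl gives the first comparison that isolates a single change, and in this assay it amounts to a 1.3-fold higher number from compound 1 to compound 3 (0.11 log units; within the scatter) for this swap. The earlier pair could not show this, since compound 1 and compound 2 differ in more than one place; here a change in the methoxy pattern of the aryl group on the sulfonyl sulfur leaves compound 3 indistinguishable from compound 1 in this assay within the usual scatter. No independent evidence bears on this result.

The gap between compound 1 and compound 2 remains unassigned, so the compounds shown do not tell whether the 2-bromophenyl group on the sulfonyl sulfur or the other point of difference accounts for the lower number of compound 2. Also open, from the compounds shown here alone, is whether an unsubstituted phenyl, or an aryl group bearing an amine or a carboxylic acid, on the sulfonyl sulfur would stay as close to compound 1 as the 4-methoxyphenyl group of compound 3 does.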